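Notes on a styrene-side change from compound 2 to compound 3

The source may report more compounds than this note shows. Statements on the series, on what has been measured and on what is new or still open speak of the compounds shown alone.

Compound 2 `CC(=O)OC[C@H]1O[C@@H](n2cc(CN3C(=O)/C(=C\c4ccc5ccccc5c4)c4ccccc43)nn2)[C@H](OC(C)=O)[C@@H](OC(C)=O)[C@@H]1OC(C)=O` holds the highest of the two numbers in a functional assay on A549 cells (Homo sapiens) for cytotoxicity, read by sulforhodamine B assay, with a stated time of 48 h; a higher number here means a weaker inhibitor, a lower number a stronger inhibitor: compound 2 gives 62200 nM, while compound 1 `CC(=O)OC[C@H]1O[C@@H](n2cc(CN3C(=O)/C(=C\c4ccc(C)cc4)c4ccccc43)nn2)[C@H](OC(C)=O)[C@@H](OC(C)=O)[C@@H]1OC(C)=O` gives 16500 nM. Compound 3 `CCC/C=C1\C(=O)N(Cc2cn([C@@H]3O[C@H](COC(C)=O)[C@@H](OC(C)=O)[C@H](OC(C)=O)[C@H]3OC(C)=O)nn2)c2ccccc21` carries propyl in place of naphthalen-2-yl on a double-bonded chain carbon bound to a double-bonded ring carbon. Within the data shown here, only one step bears on this: a 3.8-fold higher number from compound 1 to compound 2 (0.58 log units; beyond the scatter), and there the larger aromatic group raised the number. A propyl is smaller still, yet no alkyl has been measured, so the direction is uncertain. A modest drop is expected for compound 3, a 2.1-fold lower number from compound 2 to compound 3 (0.32 log units; beyond the scatter). In this assay compound 3 is estimated at 30000 nM, within 8000 nM to 120000 nM.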

Compound 3, half-maximal inhibitory concentration: 40400 nM
Beside the measured number, compound 3's estimate is 1.3-fold (0.13 log units) below it, within the range that was stated.
By their numbers in this assay, from the lowest: compound 1; then compounds 3 and 2 (each within the scatter of the next).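

In this assay, among these compounds, the first alkyl group at this position gives a 1.5-fold lower number from compound 2 to compound 3 (0.19 log units; within the scatter), so propyl and naphthalen-2-yl cannot be told apart here. Against the third compound, the step is a 2.4-fold higher number from compound 1 to compound 3 (0.39 log units; beyond the scatter), which leaves 4-methylphenyl alone with the lowest number and shows that heavy-atom count does not order these three groups. No available measurement gives a reason for these steps.

Still open, from the compounds shown here alone, is whether a longer chain, an amine or a carboxylic acid at this place would bring the number below that of compound 1.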